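Benzyl extension on the dimethoxy core series

The compounds below may be only part of what the source reports. "The series", "measured", "known", "first", "only" and "open" are said of these compounds alone.

compound 1 `COc1cc2nc(C3CCC3)nc(N3CCN(c4ccccc4C)CC3)c2cc1OC` — in an in vitro assay on U2OS cells for agonist activity at neurotensin receptor type 2 (Homo sapiens), read by reporter gene assay and beta-arrestin recruitment (a lower number here means that less compound is needed, a higher number that more compound is needed for the effect), compound 1 gives only an assay limit, > 80000 nM.
compound 2 `COc1cc2ncnc(N3CCN(c4ccccc4OC)CC3)c2cc1OC` — compound 2 likewise gives only a limit, > 80000 nM.
compound 3 `COc1cc2nc(C)nc(N3CCN(c4ccccc4OC)CC3)c2cc1OC` — compound 3 also gives only a limit, > 80000 nM.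

Compound 3 therefore stands at the limit with no number of its own, as do the other two; the limit of > 80000 nM in this assay, at which 3 of the 3 values shown sit, sums this up. Within the data shown here, the one single-point comparison within the set, a step that the two limits leave unreadable from compound 2 to compound 3, cannot be read because both ends are limits. Compound 4 `COc1cc2nc(Cc3ccccc3)nc(N3CCN(c4ccccc4OC)CC3)c2cc1OC` differs from compound 3 by phenyl in place of hydrogen on a saturated chain carbon bound to an aromatic carbon. Among the measured compounds shown here, no measured step bears on this change, and nothing in the set points in either direction. Compound 4 is expected to remain at or near the limit, the estimated step being a number no higher from compound 3 to compound 4 (the limit leaves the size open). The estimate for compound 4 is 80000 nM, with an expected range of 15000 nM to 300000 nM.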

Compound 4, half-maximal effective concentration: > 80000 nM
Compound 4: a limit, no number; the forecaster's own chance of this, stated with the estimate: 70%; the middle value lies on the limit itself.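

Among these compounds, compound 4 gives only a limit as well, so no step from compound 2 or compound 3 to compound 4 can be read: the limit of > 80000 nM in this assay, at which 4 of the 4 values shown sit. The compounds shown leave open which change on the shared core would give a measurable value in this assay.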